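Swapping an Ethylphenyl Arm for a Chlorofluorophenyl Arm

A few compounds are considered here, and "the series" means these few. Any claim that something is new, unique, unknown or untested is made for them only; others in the source may bear on it.

Measured compounds:
Compound 1, `Cc1cc(C)cc(-c2nnc(COc3cnn(C(C)(C)C)c(=O)c3Cl)o2)c1`, in a functional assay on the whole organism for inhibition, with Mythimna separata as the target, with a stated time of 5 days (a lower number here means that less compound is needed, a higher number that more compound is needed for the effect), gives only a limit, > 299000 nM, not a number.
Compound 2, `CC(C)(C)n1ncc(OCc2nnc(-c3cccc(F)c3)o2)c(Cl)c1=O`, in this assay gives 7100 nM.
Compound 3, `CCc1ccc(-c2nnc(COc3cnn(C(C)(C)C)c(=O)c3Cl)o2)cc1`, in this assay gives 14500 nM.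

All three share one core and differ only in the aromatic ring hanging from it. Of the two numbers shown, compound 3 stands highest; the only other number lies a modest step away, a 2.0-fold higher number from compound 2 to compound 3 (0.31 log units; beyond the scatter). Compound 1 sits at a limit, (the limit of > 299000 nM in this assay, at which 1 of the 3 values shown sits), so its steps to the others, an at least 42-fold lower number from compound 1 to compound 2 (1.62 log units; beyond the scatter) and an at least 20-fold lower number from compound 1 to compound 3 (1.31 log units; beyond the scatter), are known only as lower bounds, both large.

Compound 4, `CC(C)(C)n1ncc(OCc2nnc(-c3ccc(Cl)cc3F)o2)c(Cl)c1=O`, differs from compound 3 in one place: 4-chloro-2-fluorophenyl in place of 4-ethylphenyl on an aromatic carbon. The step that bears most on this change is the modest one, a 2.0-fold higher number from compound 2 to compound 3 (0.31 log units; beyond the scatter), in which a halogen-bearing ring gave the lower number and the alkyl-bearing ring the higher one. Compound 4 again carries halogens, so a modest move toward a lower number is expected in this assay, with the large steps from the limit of compound 1 suggesting that halogenated rings need not fall back toward that limit.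

For compound 4 the expected value in this assay is 6000 nM, in a range from 1500 nM to 25000 nM, a step of a 2.4-fold lower number from compound 3 to compound 4 (0.38 log units; beyond the scatter).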

Compound 4, half-maximal effective concentration: 10400 nM
For compound 4 the middle estimate is 1.7-fold (0.24 log units) below the measured one; low and high end bracket the measured number.
By their numbers in this assay, from the lowest: compounds 2, 4 and 3 (each within the scatter of the next, the first and the last beyond it). At a limit, above all of these: compound 1.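

In this assay, 4-chloro-2-fluorophenyl in place of 4-ethylphenyl gives a 1.4-fold lower number from compound 3 to compound 4 (0.14 log units; within the scatter), and in place of 3-fluorophenyl it gives a 1.5-fold higher number from compound 2 to compound 4 (0.17 log units; within the scatter). The halogen-against-alkyl contrast suggested by compound 2 and compound 3 therefore does not extend to this second halogen-bearing ring, and these three different rings are hard to tell apart at this position. The 3,5-dimethylphenyl ring remains the one clear outlier, with an at least 28-fold lower number from compound 1 to compound 4 (1.45 log units; beyond the scatter), but this size is only a bound, and compound 1 still has no actual number: the limit of > 299000 nM in this assay, at which 1 of the 4 values shown sits.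

The rings shown carry only fluorine, chlorine, methyl or ethyl, so it remains open how a phenyl ring bearing an amine or a carboxylic acid would behave at this position. It is also unclear whether the sharp loss seen with compound 1 goes with having two methyl groups or with their placement on the ring, a question that a phenyl ring with a single methyl group could begin to answer.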